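Working notes: removing the methyl from compound 3

This account rests on a few compounds, and the source may have more. Where it says the series, first, only, none or still open, it means among the compounds named here.

- compound 1 `O=C1CC(c2c(-c3ccc[nH]3)[nH]c3ccccc23)C(=O)N1`: 2000 nM
- compound 2 `COc1ccc2[nH]c3c4cn[nH]c4c4c(c3c2c1)C(=O)NC4=O`: 37000 nM
- compound 3 `Cc1ccc2[nH]c3c4cn[nH]c4c4c(c3c2c1)C(=O)NC4=O`: 2000 nM

All values come from a functional assay on B16-F10 cells (Mus musculus) for cytotoxicity, read by MTT assay, with a stated time of 72 h; on this read-out higher numbers stand for weaker inhibition and lower numbers for stronger inhibition. Compound 3 at 2000 nM stands level with compound 1, the two sharing the lowest of the three numbers, while compound 2 lies far higher.

The next structure is compound 4 `O=C1NC(=O)c2c1c1[nH]ncc1c1[nH]c3ccccc3c21`, which has hydrogen in place of methyl on an aromatic carbon.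

Going by the values given here, the only measured step that bears on this change is a 19-fold lower number from compound 2 to compound 3 (1.27 log units; beyond the scatter), with methyl in place of methoxy on an aromatic carbon. Among the compounds with values here, that step is large, but no measurement yet shows how hydrogen compares with methyl. A change of similar size is not expected in this assay, and no clear direction can be assigned. The expected step is a 1.3-fold higher number from compound 3 to compound 4 (0.10 log units; within the scatter), which would lie within the scatter. Compound 4 is estimated at 2500 nM, with an expected range of 700 nM to 10000 nM.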

Compound 4, half-maximal inhibitory concentration: 75000 nM
Compound 4: the middle estimate sits 30-fold (1.48 log units) below what was measured; the whole stated range lies below it.
By their numbers in this assay, from the lowest: compounds 1 and 3 (each within the scatter of the next); then compound 2; then compound 4.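

Taking the methyl off this aromatic carbon is far from a neutral change: in this assay it gives a 38-fold higher number from compound 3 to compound 4 (1.57 log units; beyond the scatter) and undoes the low number of compound 3. Hydrogen also differs from methoxy at this position, with a 2.0-fold higher number from compound 2 to compound 4 (0.31 log units; beyond the scatter) being a much smaller step, so of the three groups compared here on the shared core, only methyl gives a low number, while methoxy and hydrogen both lie far higher. No measured evidence is available to explain this order.

On these data alone, it remains open whether the low number is particular to methyl or would also be seen with an ethyl group, chlorine or trifluoromethyl on the same carbon. An amine or a carboxylic acid there would test the position with a different kind of group.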